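The source may report more compounds than this note shows. Statements on the series, on what has been measured and on what is new or still open speak of the compounds shown alone.

Compound 2 `CCc1cnc(N2CC=C(c3nc(COc4ccc(-n5cnnn5)cc4)cs3)CC2)nc1` is the reference point of this step. In a functional assay on isolated protein for agonist activity at Glucose-dependent insulinotropic receptor (Homo sapiens), read by HTRF and cAMP accumulation (on this read-out lower numbers stand for an effect already at smaller amounts and higher numbers for an effect only at larger amounts of compound), compound 2 gives 4.9 nM. Within the data shown here, compound 1 `CC(C)(C)OC(=O)N1CC=C(c2nc(COc3ccc(-n4cnnn4)cc3F)cs2)CC1` shares the core but carries a tert-butyl carbamate in place of the ethyl-substituted heteroaryl group, and also a fluoro; in this assay compound 1 gives 108 nM, a higher number than that of compound 2 by a margin beyond the usual scatter, so compound 2 stands lowest of the two numbers known. Compound 3 `CCc1ccc(N2CC=C(c3nc(COc4ccc(-n5cnnn5)cc4)cs3)CC2)nc1` has no result in this assay: for compound 3 the entry reads "not determined" (no result reported). Compound 4 `CCc1cnc(N2CC=C(c3nc(COc4ccc(-n5cnnn5)cc4F)cs3)CC2)nc1` differs from compound 2 in one place: fluoro in place of hydrogen on an aromatic carbon. Among the measured compounds shown here, compound 1 and compound 2 differ in more than this one place, and their two values do not isolate the effect of the fluoro alone; no measured pair does. The addition of a single fluorine at this position is expected to leave the number near where compound 2 stands, with no step beyond the scatter in either direction. Compound 4 is therefore estimated at 5 nM, within a range from 1.5 nM to 15 nM, which means an expected step of a 1.0-fold higher number from compound 2 to compound 4 (0.01 log units; within the scatter).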

Compound 4, half-maximal effective concentration: 8.8 nM
Estimate against measurement, compound 4: 1.8-fold (0.25 log units) below; low and high end bracket the measured number.
By their numbers in this assay, from the lowest: compounds 2 and 4 (each within the scatter of the next); then compound 1.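

In this assay, fluoro in place of hydrogen on this aromatic carbon, ortho to a large group and meta to the 1H-tetrazol-1-yl group, can now be read alone: it gives a 1.8-fold higher number from compound 2 to compound 4 (0.25 log units; within the scatter), so this position accepts the fluoro without a step beyond the scatter. With the fluoro present on both sides, 5-ethylpyrimidin-2-yl in place of tert-butoxycarbonyl on the amine nitrogen in a ring gives a 12-fold lower number from compound 1 to compound 4 (1.09 log units; beyond the scatter), and this exchange of groups is now also seen by itself. Nothing available here explains why either step has the size it has.

The compounds shown leave open what a chloro or methoxy group on this aromatic carbon would do. They also leave open whether a longer chain in place of the ethyl of the 5-ethylpyrimidin-2-yl group would give a similar number.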